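This account rests on a few compounds, and the source may have more. Where it says the series, first, only, none or still open, it means among the compounds named here.

Measured so far:
compound 1, `Cc1ccnc(/C(N)=N/NC(=S)N2CCSCC2)c1`, 39.2%;
compound 2, `Cc1cccc(/C(N)=N/NC(=S)N2CCCCC2)n1`, 83.5%;
compound 3, `Cc1cccc(/C(N)=N/NC(=S)N2CCCC2)n1`, 79.2%.

In a functional assay on HeLa cells (Homo sapiens) for cytotoxicity, read by MTT assay, with a stated time of 72 h, tested at 10 uM (on this read-out lower numbers stand for less inhibition of growth and higher numbers for more inhibition of growth at the one concentration tested), compound 1 gives 39.2%, the lowest of the three numbers; compound 3 gives 79.2% and compound 2 gives 83.5%, both beyond the scatter above it. Compound 4, `Cc1ccnc(/C(N)=N/NC(=S)N2CCOCC2)c1`, differs from compound 1 by morpholin-4-yl in place of thiomorpholin-4-yl on a thiocarbonyl carbon. For the measured compounds named here, the only measured step, a number 4.3 percentage points lower from compound 2 to compound 3 (within the scatter), swaps the ring on the thiocarbonyl carbon of a different core and stays within the scatter. Going by the values given here, no measured step exchanges thiomorpholin-4-yl for morpholin-4-yl, so nothing here points to a move beyond the scatter, and a step of about a number 1.2 percentage points lower from compound 1 to compound 4 (within the scatter) is expected. Compound 4 is therefore estimated at 38%, within a range from 20% to 56%.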

Compound 4, percent growth inhibition at one concentration: 49.1%
The estimate for compound 4 lay 11.1 percentage points below the measured number, within the range that was stated.
By their numbers in this assay, from the lowest: compounds 1 and 4 (each within the scatter of the next); then compounds 3 and 2 (each within the scatter of the next).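

In this assay, morpholin-4-yl in place of thiomorpholin-4-yl on a thiocarbonyl carbon gives a number 9.9 percentage points higher from compound 1 to compound 4 (within the scatter). For the compounds shown here, this is the first step read on the core of compound 1, and it shows that exchanging the ring's sulfur for oxygen here does not move the number beyond the scatter. Nothing measured here bears on the reason for this result.

Open, from the compounds shown here alone, is how piperidin-1-yl or pyrrolidin-1-yl would read on this core. Also open, going by these compounds, is what a 4-methylpiperazin-1-yl ring or an open-chain dimethylamino group would give at this position.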